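Chalcone series: lipophilicity and the carbonyl-side aryl group

The source may hold more compounds than are shown below. What is called first, only, known or untested is meant among the compounds shown, and "the series" means these compounds.

Of the compounds shown here, three have been measured in a physicochemical assay for lipophilicity, read by HPLC, at pH 7.4; a lower number here means a more polar compound, a higher number a more lipophilic compound. Compound 1 `COc1ccc(C(=O)/C=C/c2ccc(OCCNc3ccnc4cc(Cl)ccc34)c(OC)c2)c(OC)c1` gives 4.2, the lowest of the three numbers. Compound 2 `COc1ccc(C(=O)/C=C/c2ccc(O)c(CN3CCN(c4ccnc5cc(Cl)ccc45)CC3)c2)c(OC)c1` gives 5.3, and compound 3 `COc1ccc(C(=O)/C=C/c2cc(CN3CCN(c4ccnc5cc(Cl)ccc45)CC3)c(O)c(OC)c2)c(OC)c1` gives 5. Among the measured compounds shown here, the only single-point step among the measured compounds is a number 0.30 log units lower from compound 2 to compound 3 (within the scatter). Against compound 1, the nearest number is that of compound 3, which lies beyond the scatter, and compound 2 lies further still.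

Compound 4 `COc1cc(/C=C/C(C)=O)ccc1OCCNc1ccnc2cc(Cl)ccc12` is not yet measured. It differs from compound 1 in one place: methyl in place of 2,4-dimethoxyphenyl on a carbonyl carbon. For the measured compounds named here, none of the measured steps covers a change of this kind; the one step on record, from compound 2 to compound 3, concerns a single methoxy group and stays within the scatter, so it gives little guidance on removing a whole six-membered ring together with two methoxy groups. On the count of what leaves and what enters, a step in this assay well beyond the scatter is expected, downward. The expected step is a number 1.70 log units lower from compound 1 to compound 4 (beyond the scatter). Compound 4 is therefore estimated at 2.5, with a range from 1.7 to 3.3.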

Compound 4, distribution coefficient: 3
Compound 4: middle estimate off by 0.50 log units, on the low side, within the range that was stated.
By their numbers in this assay, from the lowest: compound 4; then compound 1; then compounds 3 and 2 (each within the scatter of the next).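

In this assay, the position on the carbonyl carbon now has its first reading: putting methyl in place of 2,4-dimethoxyphenyl gives a number 1.20 log units lower from compound 1 to compound 4 (beyond the scatter). Among the compounds shown here, this position therefore responds to the change by more than the scatter, whereas the only earlier step, a number 0.30 log units lower from compound 2 to compound 3 (within the scatter), concerns a methoxy group at a different place and stays within the scatter. No measurement is available that accounts for the size of this step.

The change removes the six-membered aromatic ring and both methoxy groups together, so the compounds shown cannot divide the step between them; an unsubstituted phenyl group on the same carbonyl carbon would separate the two contributions, and an ethyl group would show how the number moves with a small increase from methyl. As far as these compounds go, the step also rests on a single pair built on the core of compound 1, so whether the same change gives a similar step on the core of compound 2 or compound 3 remains open.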